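Removing the trifluoromethyl from the triazole of compound 2

The source may hold more compounds than are shown below. What is called first, only, known or untested is meant among the compounds shown, and "the series" means these compounds.

The series shares one core carrying a triazole, seen in compound 1 `Fc1ccccc1Cc1nc(-c2nc(C(F)(F)F)n[nH]2)c2ccccn12`, compound 2 `Fc1ccccc1Cc1nc(-c2nc(C(F)(F)F)n[nH]2)n2ccccc12` and compound 3 `Cc1ncc(Cc2nc(-c3nc(C(F)(F)F)n[nH]3)n3ccccc23)cn1`. In a physicochemical assay for lipophilicity, measured as octanol-water partition, at pH 7.4 (a lower number here means a more polar compound, a higher number a more lipophilic compound), compound 1 gives 3.9, compound 2 gives 3.8 and compound 3 gives 2.1. Compound 2 stands second highest of the three; its nearest neighbour is compound 1, within the scatter, and its furthest is compound 3. Within the data shown here, the one measured step, a number 1.70 log units lower from compound 2 to compound 3 (beyond the scatter), concerns the group on the saturated chain carbon, not the triazole.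

Compound 4 `Fc1ccccc1Cc1nc(-c2ncn[nH]2)n2ccccc12` differs from compound 2 in hydrogen in place of trifluoromethyl on an aromatic carbon. Among the measured compounds shown here, no measured step changes this position, so nothing in the present data sets the size of the step directly. With four heavy atoms leaving and a hydrogen entering, a decrease in this assay beyond the scatter is nonetheless expected, estimated at a number 1.00 log units lower from compound 2 to compound 4 (beyond the scatter). Compound 4 is therefore expected to give about 2.8, in a range from 2.2 to 3.4.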

Compound 4, distribution coefficient: 3.3
Estimate against measurement, compound 4: 0.50 log units below; low and high end bracket the measured number.
By their numbers in this assay, from the lowest: compound 3; then compound 4; then compounds 2 and 1 (each within the scatter of the next).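

In this assay, among these compounds, hydrogen in place of trifluoromethyl on the aromatic carbon of the triazole gives a number 0.50 log units lower from compound 2 to compound 4 (beyond the scatter), the first measured step at this position. The group on this carbon therefore does move the number, although the step is modest, and the largest step shown remains the one at the saturated chain carbon, a number 1.70 log units lower from compound 2 to compound 3 (beyond the scatter). Nothing in the data shown accounts for the size of the step at the triazole.

The compounds shown leave open how a methyl, an amine or a carboxylic acid on this triazole carbon would read in this assay, as only trifluoromethyl and hydrogen appear there. Also open, going by these compounds, is whether the same exchange gives a step of similar size on the core of compound 1 or alongside the 2-methylpyrimidin-5-yl group of compound 3.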